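Fluorophenyl isomer of compound 1: expected exposure

A few compounds are considered here, and "the series" means these few. Any claim that something is new, unique, unknown or untested is made for them only; others in the source may bear on it.

compound 1 `O=C(Nc1ccc(F)c(-c2nc3ncc(-c4ccc(F)cc4)cc3[nH]2)c1)N1CCCC1`: 6270 nM
compound 2 `Cc1nc(C)c(C(=O)Nc2ccc(F)c(-c3nc4ncc(-c5ccccc5Cl)cn4n3)c2)o1`: 39300 nM
compound 3 `O=C(Nc1ccc(F)c(-c2nc3ncc(C(F)(F)F)cc3[nH]2)c1)N1CCCC1`: 1080 nM

In an ADME assay on the whole organism (Mus musculus, strain Swiss Webster) for pharmacokinetics, read by LC-MS, at a dose of 50 mg/kg by the oral route (on this read-out lower numbers stand for lower exposure and higher numbers for higher exposure at the dose given), compound 1 is second highest of the three, below compound 2 and above compound 3. Compound 4 `O=C(Nc1ccc(F)c(-c2nc3ncc(-c4ccccc4F)cc3[nH]2)c1)N1CCCC1` carries 2-fluorophenyl in place of 4-fluorophenyl on an aromatic carbon, counted as 2-fluorophenyl in place of 4-fluorophenyl on an aromatic carbon with the same atoms joined differently. Among the compounds with values here, the one measured step at this place is a 5.8-fold lower number from compound 1 to compound 3 (0.76 log units; beyond the scatter) on exchanging 4-fluorophenyl for trifluoromethyl. Within the data shown here, that exchange removes the whole ring, and no measured step moves the fluorine on it, so its size does not carry over. The expected change is a 1.1-fold lower number from compound 1 to compound 4 (0.06 log units; within the scatter) and so none beyond the scatter. Compound 4 is estimated at 5500 nM with an expected range of 2200 nM to 14000 nM in this read-out.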

Compound 4, maximal plasma concentration: 2230 nM
Beside the measured number, compound 4's estimate is 2.5-fold (0.39 log units) above it, within the range that was stated.
By their numbers in this assay, from the lowest: compound 3; then compound 4; then compound 1; then compound 2.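

In this assay moving the fluorine on the ring, with the same atoms joined differently, gives a 2.8-fold lower number from compound 1 to compound 4 (0.45 log units; beyond the scatter) and so shows that the fluorine's place on this ring matters, not only the ring's presence. The exchange of trifluoromethyl for the ring gives a 2.1-fold higher number from compound 3 to compound 4 (0.31 log units; beyond the scatter) even with the fluorine in its 2-fluorophenyl place, so compound 4 keeps part of the margin held by compound 1. On these data alone, how far the ring itself can be changed stays open in this assay for an unsubstituted phenyl or a pyridine ring at this place. No measured evidence accounts for the effect of the fluorine's place.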